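The source may hold more compounds than are shown below. What is called first, only, known or untested is meant among the compounds shown, and "the series" means these compounds.

Among the measured compounds shown here, in an ADME assay on THP-1 cells (Homo sapiens) for cytotoxicity (a higher number here means that more compound is tolerated, a lower number that less compound is tolerated), compound 3 `O=C(Nc1ccc(C(F)(F)F)cc1)c1c(NC(=O)C(F)(F)F)sc2c1CCCCC2` gives 17200 nM, the only real number among the three measured values. Compound 2 `O=C(Nc1ccccc1)c1c(NC(=O)C(F)(F)F)sc2c1CCCCC2` gives > 50000 nM, which is a limit of the assay and not a number. Compound 1 `COc1ccc(CNC(=O)c2c(NC(=O)C(F)(F)F)sc3c2CCCCC3)cc1` gives > 50000 nM, again a limit. The step from compound 2 to compound 3 is an at least 2.9-fold lower number from compound 2 to compound 3 (0.46 log units; beyond the scatter), and the step from compound 1 to compound 3 is an at least 2.9-fold lower number from compound 1 to compound 3 (0.46 log units; beyond the scatter). The step that the two limits leave unreadable from compound 1 to compound 2 cannot be sized because the limit of > 50000 nM in this assay, at which 2 of the 3 values shown sit, covers both of its ends.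

Compound 4 `COc1cccc(NC(=O)c2c(NC(=O)C(F)(F)F)sc3c2CCCCC3)c1` has not yet been measured. It differs from compound 3 in one place: 3-methoxyphenyl in place of 4-(trifluoromethyl)phenyl on an amide-type nitrogen. For the measured compounds named here, the trifluoromethyl, whose entry in the step of an at least 2.9-fold lower number from compound 2 to compound 3 (0.46 log units; beyond the scatter) produced the only measurable number, now leaves the molecule, and the two compounds without it both sit at the limit of > 50000 nM in this assay, at which 2 of the 3 values shown sit. On that basis the number for compound 4 is expected to move back toward that limit, and the estimated step is a 2.3-fold higher number from compound 3 to compound 4 (0.37 log units; beyond the scatter). Compound 4 is therefore expected to give about 40000 nM in this assay, with a likely range from 15000 nM to 60000 nM, and a fair chance that only a limit is reported.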

Compound 4, half-maximal cytotoxic concentration: 37600 nM
Beside the measured number, compound 4's estimate is 1.1-fold (0.03 log units) above it, within the range that was stated.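

In this assay, 3-methoxyphenyl in place of 4-(trifluoromethyl)phenyl on the amide-type nitrogen gives a 2.2-fold higher number from compound 3 to compound 4 (0.34 log units; beyond the scatter), so this position can move the number upward again without returning it to a limit, and a measurable number no longer belongs to the trifluoromethyl compound alone. Methoxy in place of hydrogen on an aromatic carbon gives an at least 1.3-fold lower number from compound 2 to compound 4 (0.12 log units; that floor lies within the scatter), and 3-methoxyphenyl in place of 4-methoxybenzyl gives an at least 1.3-fold lower number from compound 1 to compound 4 (0.12 log units; that floor lies within the scatter). These two steps are only floors, and compound 4 may not truly differ from compound 2 or compound 1, because one end of each step is a limit and not a number: the limit of > 50000 nM in this assay, at which 2 of the 4 values shown sit.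

The compounds shown leave open whether the change from compound 3 to compound 4 comes from the identity of the group or from where it sits on the ring, as methoxy appears on a phenyl ring only in 3-methoxyphenyl and trifluoromethyl only in 4-(trifluoromethyl)phenyl. Also open, on these data alone, is how a 4-methoxyphenyl group, or a phenyl ring carrying an amine or a carboxylic acid, would read in this assay.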